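A few compounds are considered here, and "the series" means these few. Any claim that something is new, unique, unknown or untested is made for them only; others in the source may bear on it.

In an ADME assay on Vero cells (Chlorocebus sabaeus) for cytotoxicity, read by MTT assay, with a stated time of 72 h (a higher number here means a weaker inhibitor, a lower number a stronger inhibitor), compound 1, `O=[N+]([O-])c1c[nH]c(-c2nnc(-c3ccc[nH]3)o2)c1`, gives 227000 nM. Two further compounds share its core. Compound 2, `COc1cc(/C=C/c2nnc(-c3cc([N+](=O)[O-])cn3C)o2)ccc1O`, gives 203000 nM in this assay, and compound 3, `Cn1cc([N+](=O)[O-])cc1-c1nnc(-c2cc3ccccc3[nH]2)o1`, gives 109000 nM. Among these three numbers, compound 1 holds the highest, yet its distance from compound 2 lies within the usual scatter of repeated measurements, so no order between those two can be read. Only compound 3 stands beyond the scatter, with the lower number of the pair.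

Compound 4, `O=[N+]([O-])c1c[nH]c(-c2nnc(-c3ccccc3)o2)c1`, is a close relative of compound 1 that has not yet been measured in this assay. The difference between the two is phenyl in place of 1H-pyrrol-2-yl on an aromatic carbon, a single exchange on an aromatic carbon of a five-membered aromatic ring with 2 nitrogen and 1 oxygen.

Going by the values given here, no measured pair in this set isolates this exchange, so its effect in this assay is unknown. All three measured compounds cluster in a narrow band, and the phenyl for 1H-pyrrol-2-yl swap is modest. Compound 4 is therefore expected to show a step of a 1.1-fold lower number from compound 1 to compound 4 (0.05 log units; within the scatter) that stays within the scatter, in either direction. Compound 4 is accordingly estimated at 200000 nM, within a range from 100000 nM to 400000 nM.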

Compound 4, half-maximal inhibitory concentration: 423000 nM
Compound 4: middle estimate off by 2.1-fold (0.33 log units), on the low side, outside the stated range (above it).
By their numbers in this assay, from the lowest: compounds 3, 2, 1 and 4 (each within the scatter of the next, the first and the last beyond it).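

In this assay, going by these compounds alone, this pair is the first to isolate a single exchange on an aromatic carbon of the five-membered aromatic ring with 2 nitrogen and 1 oxygen, and it gives a 1.9-fold higher number from compound 1 to compound 4 (0.27 log units; within the scatter), a step that stays within the scatter. At this position, then, phenyl can stand in place of 1H-pyrrol-2-yl without a readable change in the number, even though the exchange swaps a five-membered aromatic ring with 1 hetero atom and 1 hydrogen-bond donor for a six-membered aromatic ring of carbon only with no hydrogen-bond donor. Nothing measured here speaks to why the two compounds stay so close, and the step stands without an explanation.

Going by these compounds, it remains open whether a group of another kind at this position, such as an amine, a carboxylic acid or a longer alkyl chain, would give a step beyond the scatter. On these data alone, it is also open whether a substituent placed on the phenyl of compound 4 would move the number at all.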